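Chlorine placement on the aryl group of the sulfamide series

The compounds below may be only part of what the source reports. "The series", "measured", "known", "first", "only" and "open" are said of these compounds alone.

Measured so far in a functional assay on HT-29 cells (Homo sapiens) for antiproliferative activity, read by sulforhodamine B assay, with a stated time of 48 h; a higher number here means a weaker inhibitor of growth, a lower number a stronger inhibitor of growth:
compound 1, `Cc1ccc(-c2cc(N3CCC(CCNS(N)(=O)=O)CC3)ncn2)cc1`: 52300 nM
compound 2, `NS(=O)(=O)NCCC1CCN(c2cc(-c3cccc(Cl)c3)ncn2)CC1`: 31600 nM

Compound 2 holds the lowest of the two numbers in this assay, with compound 1 the nearest at a gap that lies within the scatter, so the two compounds are not separated by these data.

Compound 3, `NS(=O)(=O)NCCC1CCN(c2cc(-c3ccccc3Cl)ncn2)CC1`, has not been measured. It differs from compound 2 in one place: 2-chlorophenyl in place of 3-chlorophenyl on an aromatic carbon. Within the data shown here, the only measured step, a 1.7-fold lower number from compound 1 to compound 2 (0.22 log units; within the scatter), exchanged the aryl group on the shared core and gave no movement beyond the scatter. Among the measured compounds shown here, no measured pair compares two chlorophenyl groups, so this step has no direct counterpart in the data. For the measured compounds named here, with the one neighbouring step flat, no change beyond the scatter is expected in this assay on going to compound 3, and the estimated step is a 1.1-fold higher number from compound 2 to compound 3 (0.04 log units; within the scatter). Going by the values given here, for compound 3 the expected value in this assay is 35000 nM, with a range from 12000 nM to 100000 nM; the range is kept wide because a 1.7-fold lower number from compound 1 to compound 2 (0.22 log units; within the scatter) is the only comparable step and it concerns a different exchange.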

Compound 3, concentration for 50% growth inhibition: 52900 nM
Compound 3: the middle estimate sits 1.5-fold (0.18 log units) below what was measured; measured number inside the range.
By their numbers in this assay, from the lowest: compounds 2, 1 and 3 (each within the scatter of the next).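

Going from the 3-chlorophenyl to the 2-chlorophenyl group, with the same atoms joined differently, gives a 1.7-fold higher number from compound 2 to compound 3 (0.22 log units; within the scatter) in this assay. Among these compounds, this is the first direct comparison of two chlorophenyl groups on this aromatic carbon, and it does not separate them. The exchange of 4-methylphenyl for 2-chlorophenyl at the same place gives a 1.0-fold higher number from compound 1 to compound 3 (0.00 log units; within the scatter), so all three pairs among the aryl groups shown lie within the scatter, and no preference at this position can be read from them; no measured information on why these compounds behave as they do is available.

As far as these compounds go, whether a carboxylic acid or an amine on the aryl group would give a step beyond the scatter in this assay remains open. Also open, from the compounds shown here alone, is whether a longer chain leading to the sulfamide, or any exchange away from the aryl position, would separate compounds on the shared core.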